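The source may hold more compounds than are shown below. What is called first, only, known or untested is meant among the compounds shown, and "the series" means these compounds.

In an ADME assay on Vero cells (Chlorocebus sabaeus) for cytotoxicity, read by sulforhodamine B assay, with a stated time of 3 days (on this read-out higher numbers stand for lower toxicity in this test and lower numbers for higher toxicity in this test), compound 1 `CC1=C(C(=O)Nc2ccc(Cl)cc2)C(c2ccccc2O)C(C(=O)Nc2ccc(Cl)cc2)=C(C)N1` gives 62 ug/mL and compound 2 `COc1ccc(NC(=O)C2=C(C)NC(=S)NC2c2ccccc2)cc1` gives 15 ug/mL while compound 3 `COc1ccc(NC(=O)C2=C(C)NC(=O)NC2c2ccco2)cc1` gives 210 ug/mL as the highest of the three numbers. Its gaps to compound 1 and to compound 2 both lie beyond the scatter, so compound 3 is the least toxic of the three in this test.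

Compound 4 `COc1ccc(NC(=O)C2=C(C)NC(=O)NC2c2ccc(N(C)C)cc2)cc1` differs from compound 3 in one place: 4-(dimethylamino)phenyl in place of furan-2-yl on a saturated ring carbon with 4-(dimethylamino)phenyl in place of furan-2-yl on a saturated ring carbon. Going by the values given here, no measured pair isolates this change. Among the compounds with values here, the only guide is that compound 1 at 62 ug/mL and compound 2 at 15 ug/mL both lack furan-2-yl and both sit lower than compound 3, but each also differs from compound 3 elsewhere, so this support is weak. In this assay a modest move to a lower number is expected, and the estimated 2.3-fold lower number from compound 3 to compound 4 (0.37 log units; beyond the scatter) would lie only just beyond the scatter. For compound 4 the estimate is 90 ug/mL with 25 ug/mL to 300 ug/mL as the expected range.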

Compound 4, half-maximal cytotoxic concentration: 236 ug/mL
For compound 4 the middle estimate is 2.6-fold (0.42 log units) below the measured one, within the range that was stated.
By their numbers in this assay, from the lowest: compound 2; then compound 1; then compounds 3 and 4 (each within the scatter of the next).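

In this assay, going by these compounds alone, replacing furan-2-yl with 4-(dimethylamino)phenyl on the saturated ring carbon gives a 1.1-fold higher number from compound 3 to compound 4 (0.05 log units; within the scatter), the first comparison that changes this position alone. On this core, the read-out therefore does not separate the five-membered aromatic ring with one hetero atom from the six-membered aromatic ring of carbon only, so furan-2-yl is not needed for a number at this level. No available measurement gives a reason for this result.

On these data alone, it remains open whether a carboxylic acid or a longer alkyl chain on the same ring carbon would leave the number at this level. As far as these compounds go, it is also open whether the same exchange would give a similar step on the core of compound 2, which carries a thiocarbonyl.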